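The source may report more compounds than this note shows. Statements on the series, on what has been measured and on what is new or still open speak of the compounds shown alone.

Compound 1, `Cc1ccc(S(=O)(=O)N[C@@H](CC(=O)NC(C)(C)C)C(=O)NCCNC(=O)c2cccc(O)c2)cc1`, in an ADME assay on Karpas-1106P cells (Homo sapiens) for cytotoxicity (on this read-out lower numbers stand for an effect already at smaller amounts and higher numbers for an effect only at larger amounts of compound), reaches only the assay limit > 11100 nM. Compound 2, `Cc1ccc(S(=O)(=O)N[C@@H](CC(=O)NC(C)(C)C)C(=O)NCCNC(=O)c2cccc(F)c2)cc1`, in this assay likewise reaches only the limit > 11100 nM.

Within the data shown here, compound 2 therefore stands nowhere on a numerical scale: its entry is a limit, and the one further value shown, that of compound 1, is a limit as well, so that the limit of > 11100 nM in this assay, at which 2 of the 2 values shown sit, holds both. Among the measured compounds shown here, the step that the two limits leave unreadable from compound 1 to compound 2 is accordingly unreadable, and it is the only measured step that bears on the next change.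

Compound 3, `Cc1ccc(S(=O)(=O)N[C@@H](CC(=O)NC(C)(C)C)C(=O)NCCNC(=O)c2ccccn2)cc1`, differs from compound 2 by pyridin-2-yl in place of 3-fluorophenyl on a carbonyl carbon. No readable step is available to size this change. Given that compound 2 sits at the limit > 11100 nM, compound 3 is expected to sit near or beyond that limit too, at an estimated 15000 nM within 5000 nM to 60000 nM. The expected step that the limit leaves unreadable from compound 2 to compound 3 is estimated as none beyond the scatter.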

Compound 3, half-maximal effective concentration: > 11100 nM
Compound 3: no number, only a limit; the forecaster's own chance of this, stated with the estimate: 70%; the middle value lies beyond the limit too.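

In this assay compound 3 reaches > 11100 nM as a limit and not a number. No step among compound 1, compound 2 and compound 3 can therefore be read, all three sharing one limit: the limit of > 11100 nM in this assay, at which 3 of the 3 values shown sit.

The compounds shown leave open at what concentration any of them would reach a half-maximal effect.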